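Aryl swap at the saturated ring carbon

This account rests on a few compounds, and the source may have more. Where it says the series, first, only, none or still open, it means among the compounds named here.

Measured so far:
compound 1 `CC1=C(C(=O)Nc2ccc(Cl)c(Cl)c2)C(c2cccc(O)c2)NC(=S)N1`: 14100 nM
compound 2 `CC1=C(C(=O)Nc2ccc(Cl)c(Cl)c2)C(c2cccc(Oc3ccccc3)c2)NC(=S)N1`: 9770 nM
compound 3 `CC1=C(C(=O)Nc2ccc(F)c(Cl)c2)C(c2cccc(Oc3ccccc3)c2)NC(=O)N1`: 22400 nM

In a functional assay on PC-3 cells (Homo sapiens) for cytotoxicity, read by sulforhodamine B assay, with a stated time of 48 h (on this read-out lower numbers stand for stronger inhibition of growth and higher numbers for weaker inhibition of growth), compound 1 gives 14100 nM, the second highest of the three numbers; its nearest neighbour is compound 2 and its furthest compound 3, and both gaps are within the scatter. Among the compounds with values here, the one single-point step measured so far, a 1.4-fold lower number from compound 1 to compound 2 (0.16 log units; within the scatter), is within the scatter as well. Compound 3 differs from compound 2 in more than one place, so its number is taken on its own.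

The unmeasured compound 4 `CC1=C(C(=O)Nc2ccc(Cl)c(Cl)c2)C(c2ccccc2Cl)NC(=S)N1` arises from compound 1 by 2-chlorophenyl in place of 3-hydroxyphenyl on a saturated ring carbon. Within the data shown here, none of the measured steps touches this saturated ring carbon, so no step bears on the change; the only measured step, a 1.4-fold lower number from compound 1 to compound 2 (0.16 log units; within the scatter), shows that a sizeable change to the same aryl ring left the number within the scatter. On that basis no step beyond the scatter is expected in this assay. Compound 4 is expected to give 12000 nM, with a range of 4500 nM to 32000 nM. This estimate amounts to a step of a 1.2-fold lower number from compound 1 to compound 4 (0.07 log units; within the scatter), expected to remain within the scatter.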

Compound 4, concentration for 50% growth inhibition: 20000 nM
For compound 4 the middle estimate is 1.7-fold (0.22 log units) below the measured one; measured number inside the range.
By their numbers in this assay, from the lowest: compounds 2, 1, 4 and 3 (each within the scatter of the next, the first and the last beyond it).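

Replacing 3-hydroxyphenyl with 2-chlorophenyl on the saturated ring carbon gives, in this assay, a 1.4-fold higher number from compound 1 to compound 4 (0.15 log units; within the scatter). The earlier step altered only the group on the oxygen of this aryl ring, whereas this one exchanges the whole aryl group for one with 0 hydrogen-bond donors and 0 hydrogen-bond acceptors, and the number still stays within the scatter, so in this pair the hydroxyl is not needed for a number of this order. No measurement is available to explain this result.

As far as these compounds go, whether an amine or a carboxylic acid on this aryl ring, or a cyclohexyl group in its place, would move the number beyond the scatter remains open. This step also changes the substituent and its place on the ring together, so the two cannot be separated.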